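The source may hold more compounds than are shown below. What is called first, only, known or untested is meant among the compounds shown, and "the series" means these compounds.

Compounds measured so far:
compound 1, `C/C(=N\NC(=O)c1ccncc1)C(=O)Nc1ccc(OC(F)(F)F)cc1` — in a functional assay on HepG2 cells (Homo sapiens) for cytotoxicity, read by MTT assay, with a stated time of 72 h (on this read-out higher numbers stand for weaker inhibition and lower numbers for stronger inhibition), compound 1 gives > 50000 nM
compound 2, `C/C(=N\NC(=O)c1ccncc1)C(=O)Nc1cc(Cl)cc(Cl)c1` — in this assay compound 2 gives > 50000 nM

The reading for compound 1 in this assay is a limit of the assay and not a number. The reading for compound 2 is likewise a limit rather than a number. Within the data shown here, both readings share the same character, (the limit of > 50000 nM in this assay, at which 2 of the 2 values shown sit), so no step between the two can be sized, and compound 1 cannot be placed above or below compound 2 beyond the fact that both sit at that limit.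

Compound 3, `C/C(=N\NC(=O)c1ccncc1)C(=O)Nc1ccc(I)cc1`, has not yet been measured in this assay. Compared with compound 1 it carries iodo in place of trifluoromethoxy on an aromatic carbon, that is, iodo in place of trifluoromethoxy on an aromatic carbon; the shared core is otherwise kept. Among the measured compounds shown here, no measured step exists on which to rest an expectation, and both compounds measured so far stand at the limit. The step from compound 1 is therefore expected to be none beyond the scatter, as a number no higher from compound 1 to compound 3 (the limit leaves the size open). Compound 3 is accordingly expected to give about 50000 nM, estimated to lie between 20000 nM and 120000 nM, most likely again reported as a limit.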

Compound 3, half-maximal inhibitory concentration: > 50000 nM
Compound 3 ended at the assay's limit; the forecaster's own chance of this, stated with the estimate: 75%; the middle value lies on the limit itself.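

No step can be read between compound 1 and compound 3, since both readings in this assay are limits of the assay and not numbers: the limit of > 50000 nM in this assay, at which 3 of the 3 values shown sit. The compounds shown leave open where the true value of each lies, and whether iodo in place of trifluoromethoxy on an aromatic carbon changes the reading at all.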